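Swapping Bromo for a Hydroxypropynyl Arm on Compound 2

The source may report more compounds than this note shows. Statements on the series, on what has been measured and on what is new or still open speak of the compounds shown alone.

Of the compounds shown here, three sharing one core have been tested in a functional assay on A-375 cells (Homo sapiens) for antiproliferative activity, read by trypan blue exclusion, with a stated time of 48 h, tested at 5 uM; a higher number here means a weaker effect of the compound at the concentration tested, a lower number a stronger effect. Compound 1 `CC(=O)Nc1nc(-c2cccc(NS(=O)(=O)c3ccc(Br)cc3)c2)cs1` gives 19.7%, compound 2 `CC(=O)Nc1nc(-c2cccc(NS(=O)(=O)c3cccc(Br)c3)c2)cs1` gives 67.4%, and compound 3 `C#Cc1ccc(S(=O)(=O)Nc2cccc(-c3csc(NC(C)=O)n3)c2)cc1` gives 38.3%. Compound 2 thus stands highest, meaning weakest, of the three; its nearest neighbour is compound 3 and its furthest is compound 1. The step to compound 4 `CC(=O)Nc1nc(-c2cccc(NS(=O)(=O)c3cccc(C#CCO)c3)c2)cs1` is 3-hydroxyprop-1-yn-1-yl in place of bromo on an aromatic carbon. Within the data shown here, two measured steps bear on it: a number 18.6 percentage points higher from compound 1 to compound 3 (beyond the scatter), where ethynyl also replaced bromo, and a number 29.1 percentage points lower from compound 2 to compound 3 (beyond the scatter). Since ethynyl in place of bromo raised the number once, a modest rise is expected. Compound 4 is therefore expected to give 76%, within 52% to 96%, an expected step of a number 8.6 percentage points higher from compound 2 to compound 4 (within the scatter).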

Compound 4, a percentage reported as activity, at one concentration (the size of the read-out at that concentration, not a potency): 66.2%
For compound 4 the middle estimate is 9.8 percentage points above the measured one, within the range that was stated.
By their numbers in this assay, from the lowest: compound 1; then compound 3; then compounds 4 and 2 (each within the scatter of the next).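

In this assay, the position meta to a large group takes 3-hydroxyprop-1-yn-1-yl in place of bromo with a number 1.2 percentage points lower from compound 2 to compound 4 (within the scatter), so the triple bond and hydrogen-bond donor that enter leave the reading unchanged within the scatter. The earlier swap of ethynyl for bromo, on the 4-bromophenyl compound, gave a number 18.6 percentage points higher from compound 1 to compound 3 (beyond the scatter), so a change of this kind does not move the number equally in both series. Nothing measured here accounts for this result. From the compounds shown here alone, what an amine or a carboxylic acid at the end of this arm would do remains open, as does whether any arm at this position can bring the number down.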